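The compounds below may be only part of what the source reports. "The series", "measured", "known", "first", "only" and "open" are said of these compounds alone.

Measured so far in a physicochemical assay for solubility, in phosphate buffer, measured as kinetic solubility, with a stated time of 1 h, at pH 7.4; a higher number here means a more soluble compound, a lower number a less soluble compound:
compound 1 `Cc1cc(C)cc(NC(=O)COc2cc(C)nc3ccc(C)cc23)c1` gives 83000 nM
compound 2 `COc1ccc2nc(C)cc(OCC(=O)Nc3cc(C)ccc3C)c2c1` gives 45500 nM
compound 3 `COc1ccc2nc(C)cc(OCC(=O)Nc3ccc(Cl)c(C(F)(F)F)c3)c2c1` gives 17000 nM

Compound 2 stands second highest of the three numbers. Its nearest neighbour is compound 1, whose number is higher by an amount that stays within the scatter of this assay, so no order between compound 1 and compound 2 can be claimed. Compound 3 lies furthest from compound 2, with a lower number that falls beyond the scatter; compound 3 is thus the least soluble of the three as measured.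

The next compound, compound 4 `COc1ccc2nc(C)cc(OCC(=O)Nc3nccs3)c2c1`, is not yet measured. It differs from compound 2 in one place: 1,3-thiazol-2-yl in place of 2,5-dimethylphenyl on an amide-type nitrogen. Among the measured compounds shown here, no step between measured compounds covers this kind of exchange, so there is no measured precedent to lean on. The expectation is a modest move upward in this assay, a step that may well stay within the scatter, with a wide range to reflect the absence of a precedent. For compound 4 the estimate in this assay is 70000 nM, with a range from 25000 nM to 200000 nM. This estimate means a step of a 1.5-fold higher number from compound 2 to compound 4 (0.19 log units; within the scatter), expected to be small.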

Compound 4, solubility: 54000 nM
Compound 4: middle estimate off by 1.3-fold (0.11 log units), on the high side; the range from low to high includes it.
By their numbers in this assay, from the lowest: compound 3; then compounds 2, 4 and 1 (each within the scatter of the next).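

In this assay, among the compounds shown here, the exchange of 2,5-dimethylphenyl for 1,3-thiazol-2-yl on an amide-type nitrogen gives a 1.2-fold higher number from compound 2 to compound 4 (0.07 log units; within the scatter), the first step that isolates a single place. At this position, a six-membered aromatic ring of carbon only, with 8 heavy atoms and 0 hydrogen-bond acceptors, and a five-membered aromatic ring with 2 hetero atoms, with 5 heavy atoms and 2 hydrogen-bond acceptors, cannot be told apart by this read-out, so this one exchange shows that such a difference in the group can pass without a step beyond the scatter. No measured property bears on this result, and no cause can be offered for it.

From the compounds shown here alone, whether the same exchange would read the same way on the core of compound 1 remains open, as this single pair is all that speaks for the position. Also open, going by these compounds, is whether a group of another kind on the same amide-type nitrogen, such as an aliphatic amine, a carboxylic acid or a longer chain, would give a step beyond the scatter in this assay.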